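This account rests on a few compounds, and the source may have more. Where it says the series, first, only, none or still open, it means among the compounds named here.

Compound 1 `CCOc1ccc(C(=O)/C=C/c2ccc(C(=O)Nc3cccc(-c4cc(C(=O)OC)no4)c3)cc2)cc1` belongs to a set of three related molecules that have been tested in an ADME assay on Vero cells (Chlorocebus sabaeus) for cytotoxicity, read by MTT assay, with a stated time of 72 h; on this read-out lower numbers stand for higher toxicity in this test and higher numbers for lower toxicity in this test. In this assay compound 1 gives > 40 ug/mL, which is a limit of the assay and not a number. Compound 2 `COC(=O)c1cc(-c2cccc(NC(=O)c3ccc(/C=C/C(=O)c4ccc(Br)cc4)cc3)c2)on1` carries bromo in place of ethoxy on an aromatic carbon. In this assay compound 2 gives > 20 ug/mL, again a limit. Compound 3 `COC(=O)c1cc(-c2cccc(NC(=O)c3ccc(/C=C/C(=O)c4ccc(CC(C)C)cc4)cc3)c2)on1` carries isobutyl in place of ethoxy on an aromatic carbon. In this assay compound 3 gives > 10 ug/mL, also a limit. The steps a step that the two limits leave unreadable from compound 1 to compound 2, a step that the two limits leave unreadable from compound 1 to compound 3 and a step that the two limits leave unreadable from compound 2 to compound 3 are all unreadable in size: with the three values sitting at the limits (the limit of > 10 ug/mL in this assay, at which 1 of the 3 values shown sits), the limit of > 20 ug/mL in this assay, at which 1 of the 3 values shown sits, and (the limit of > 40 ug/mL in this assay, at which 1 of the 3 values shown sits), neither size nor direction can be read. Compound 4 `COC(=O)c1cc(-c2cccc(NC(=O)c3ccc(/C=C/C(=O)c4ccc(Cl)cc4)cc3)c2)on1` differs from compound 1 by chloro in place of ethoxy on an aromatic carbon. The closest measured change, to bromo, gave no readable size, so no step beyond the scatter is expected in this assay. Compound 4 is therefore expected to give about 40 ug/mL, between 15 ug/mL and 100 ug/mL, most likely again reported only as a limit. The step of a number no higher from compound 1 to compound 4 (the limit leaves the size open) is thus expected to be small.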

Compound 4, half-maximal cytotoxic concentration: > 50 ug/mL
Compound 4: no number, only a limit; the forecaster's own chance of this, stated with the estimate: 85%; at least 1.2-fold (0.09 log units) between middle value and limit.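

In this assay compound 4 gives > 50 ug/mL, a limit of the assay and not a number. The steps to compound 4 from compound 1, compound 2 and compound 3 cannot be read. The compounds shown leave open where any of the four true values lies, and whether swapping this group changes cytotoxicity at all.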